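A few compounds are considered here, and "the series" means these few. Any claim that something is new, unique, unknown or untested is made for them only; others in the source may bear on it.

Measured so far in a functional assay on CHO cells for antagonist activity at Glucagon receptor (Homo sapiens), read by cAMP accumulation, with stated times of 30 min and 45 min; a lower number here means a stronger inhibitor, a higher number a weaker inhibitor:
compound 1 `CC(C)(C)CC[C@H](c1ccc(C(=O)NCc2nn[nH]n2)cc1)N1C(=O)C(c2cccc(C(F)(F)F)c2)=N[C@]12CC[C@@H](C(C)(C)C)CC2` — 180 nM
compound 2 `CC(C)(C)CC[C@H](c1ccc(C(=O)NCc2nn[nH]n2)cc1)N1C(=O)C(c2ccc(F)cc2)=N[C@]12CC[C@@H](C(C)(C)C)CC2` — 240 nM

In this assay compound 2 gives 240 nM, the higher of the two numbers; the nearest neighbour, compound 1, gives 180 nM. The step of a 1.3-fold higher number from compound 1 to compound 2 (0.12 log units; within the scatter) lies within the scatter, so no order between the two can be claimed from these data. Compound 3 `CC(C)(C)CC[C@H](c1ccc(C(=O)NCc2nn[nH]n2)cc1)N1C(=O)C(c2cnccc2C(F)(F)F)=N[C@]12CC[C@@H](C(C)(C)C)CC2` differs from compound 2 in one place: 4-(trifluoromethyl)pyridin-3-yl in place of 4-fluorophenyl on a carbon with a double bond to nitrogen. For the measured compounds named here, the only measured step that bears on this change is the earlier swap of the aryl group on the same carbon, a 1.3-fold higher number from compound 1 to compound 2 (0.12 log units; within the scatter), which stayed within the scatter. Going by the values given here, a pyridine ring at this position has no measured precedent, so the comparison rests on one step only. On that basis no step beyond the scatter is expected in either direction. Compound 3 is therefore expected to give about 200 nM, in the range 70 nM to 600 nM. The expected step is a 1.2-fold lower number from compound 2 to compound 3 (0.08 log units; within the scatter).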

Compound 3, half-maximal inhibitory concentration: 1200 nM
Estimate against measurement, compound 3: 6.0-fold (0.78 log units) below; measured number above the stated range.
By their numbers in this assay, from the lowest: compounds 1 and 2 (each within the scatter of the next); then compound 3.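

In this assay the carbon with a double bond to nitrogen proves sensitive to the aryl group it carries, although the earlier swap there stayed within the scatter: 4-(trifluoromethyl)pyridin-3-yl gives a 5.0-fold higher number from compound 2 to compound 3 (0.70 log units; beyond the scatter) against 4-fluorophenyl and a 6.7-fold higher number from compound 1 to compound 3 (0.82 log units; beyond the scatter) against 3-(trifluoromethyl)phenyl. Both steps run the same way, and since compound 1 and compound 3 each carry a trifluoromethyl group, the presence of that group alone does not keep the number low. No measurement at hand offers a reason for the rise.

On these data alone, the ring nitrogen and the place of the trifluoromethyl group change together here, so their shares in the step remain open. A 4-(trifluoromethyl)phenyl group or an unsubstituted pyridin-3-yl group on this carbon would separate them.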